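The source may hold more compounds than are shown below. What is called first, only, known or untested is meant among the compounds shown, and "the series" means these compounds.

Of the compounds shown here, three built on one shared core have been tested in a functional assay on HepG2 cells (Homo sapiens) for antiproliferative activity, with a stated time of 72 h; on this read-out lower numbers stand for an effect already at smaller amounts and higher numbers for an effect only at larger amounts of compound. Going by the values given here, compound 1 `C=CCNC(=O)n1c(-c2ccc(OC)cc2)cc(=O)c2c(OC)cc(OC)cc21` is the first of them. In this assay compound 1 gives only a limit of > 20000 nM, not a number. Compound 3 `COc1cc(OC)c2c(=O)cc(C(=O)Nc3ccc4oc(-c5ccc(F)cc5)nc4c3)[nH]c2c1` is the second. In this assay compound 3 likewise stops at the limit of > 36700 nM. Compound 2 `COc1cc(OC)c2c(=O)cc(C(=O)Nc3ccc(C4CCCCC4)cc3)[nH]c2c1` is the third. In this assay compound 2 also stands at a limit, > 43100 nM, so no number is known for it. The two other values are limits as well, and none of the three compounds can be set above or below another. Compound 4 `COc1cc(OC)c2c(=O)cc(C(=O)Nc3ccc(S(=O)(=O)c4ccccc4)cc3)[nH]c2c1` is not yet measured. It differs from compound 2 by phenylsulfonyl in place of cyclohexyl on an aromatic carbon. Among the compounds with values here, no measured pair of compounds isolates such a change, so no step size is known from the data. The step expected is an at least 1.0-fold lower number from compound 2 to compound 4 (0.03 log units; that floor lies within the scatter), that is, none beyond the usual scatter. Compound 4 is therefore estimated at 40000 nM, within a range from 10000 nM to 150000 nM, and most likely to be reported once more only as a limit.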

Compound 4, half-maximal effective concentration: > 70600 nM
Compound 4: a limit, no number; the forecaster's own chance of this, stated with the estimate: 80%; middle value at least 1.7-fold (0.24 log units) from the limit.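

In this assay compound 4 gives only a limit, > 70600 nM. Compound 2 likewise gives only a limit, > 43100 nM, so the step from compound 2 to compound 4 cannot be read. The compounds shown leave open what effect phenylsulfonyl in place of cyclohexyl has on this read-out.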